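The source may hold more compounds than are shown below. What is called first, only, known or untested is meant among the compounds shown, and "the series" means these compounds.

Measured in an ADME assay on Akata cells (Homo sapiens) for cytotoxicity, with a stated time of 7 days (a lower number here means that less compound is tolerated, a higher number that more compound is tolerated), every entry a limit:
- compound 1 `CCOc1nc(N)nc2c1ncn2/C=C1/CC1(CO)CO`: > 20000 nM
- compound 2 `CCCSc1nc(N)nc2c1ncn2/C=C1/CC1(CO)CO`: > 20000 nM
- compound 3 `CC(C)Sc1nc(N)nc2c1ncn2/C=C1/CC1(CO)CO`: > 20000 nM

Compound 3 gives > 20000 nM, which is a limit and not a number. It has company, as the series shows (the limit of > 20000 nM in this assay, at which 3 of the 3 values shown sit).

Compound 4 `CCCCCCOc1nc(N)nc2c1ncn2/C=C1/CC1(CO)CO` carries hexyloxy in place of isopropylsulfanyl on an aromatic carbon.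

For the measured compounds named here, three measured steps bear on this change: a step that the two limits leave unreadable from compound 1 to compound 2, a step that the two limits leave unreadable from compound 1 to compound 3 and a step that the two limits leave unreadable from compound 2 to compound 3. None of them has a readable size, so they set no scale for the change. The closest measured relative is compound 1, the ethoxy member, which gives > 20000 nM, again a limit. No chain as long as hexyloxy has been measured, so some movement toward lower numbers cannot be excluded.

The expected step is a number no higher from compound 3 to compound 4 (the limit leaves the size open), estimated as none beyond the scatter. For compound 4 the estimate is 20000 nM. The expected range for compound 4 runs from 8000 nM to 50000 nM, and another limit is the likeliest report.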

Compound 4, half-maximal cytotoxic concentration: > 20000 nM
Compound 4 gave a limit, no number (the forecaster's own chance of this, stated with the estimate: 80%); the middle value lies on the limit itself.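

Compound 4 returns a limit and not a number in this assay, as do compound 1, compound 2 and compound 3, so no step among these compounds can be read: the limit of > 20000 nM in this assay, at which 4 of the 4 values shown sit.

The compounds shown leave open the concentration at which any of them becomes cytotoxic in this assay, and whether the group on the aromatic carbon changes it.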